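Replacing Nitro with Amino on the Aromatic Ring

The source may report more compounds than this note shows. Statements on the series, on what has been measured and on what is new or still open speak of the compounds shown alone.

Three compounds with a shared core, differing in one group on an aromatic carbon, have been measured in a functional assay (aorta) for inhibition, with Rattus norvegicus as the target; on this read-out lower numbers stand for stronger inhibition and higher numbers for weaker inhibition. Compound 1 (`Cc1nsc(-c2ccc(N3CCN(c4cccc(Cl)c4)CC3)nn2)n1`) carries chloro and gives 0.6 nM. Compound 2 (`Cc1nsc(-c2ccc(N3CCN(c4cccc(C(F)(F)F)c4)CC3)nn2)n1`) carries trifluoromethyl and gives 0.3 nM. The data show a 2.0-fold lower number from compound 1 to compound 2 (0.30 log units; within the scatter), so these two cannot be told apart. Compound 3 (`Cc1nsc(-c2ccc(N3CCN(c4cccc([N+](=O)[O-])c4)CC3)nn2)n1`) carries nitro and gives 3 nM, the highest number of the three, which makes it the weakest inhibitor of this small set. The gaps to it are a 5.0-fold higher number from compound 1 to compound 3 (0.70 log units; beyond the scatter) and a 10-fold higher number from compound 2 to compound 3 (1.00 log units; beyond the scatter).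

Compound 4 (`Cc1nsc(-c2ccc(N3CCN(c4cccc(N)c4)CC3)nn2)n1`) has amino in place of nitro on an aromatic carbon. Among the measured compounds shown here, no measured compound carries amino, so the three steps offer only indirect guidance. They show that exchanging this one group has so far produced changes no larger than modest. The direction is not settled by the data, and a slight lean towards a higher number is only a cautious judgement. The expected change is a 1.7-fold higher number from compound 3 to compound 4 (0.22 log units; within the scatter), which is small against the uncertainty. For compound 4 the estimate is 5 nM, with an expected range from 1 nM to 25 nM.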

Compound 4, half-maximal inhibitory concentration: > 100 nM
Compound 4 ended at the assay's limit; the forecaster's own chance of this, stated with the estimate: 3%; at least 20-fold (1.30 log units) between middle value and limit.
By their numbers in this assay, from the lowest: compounds 2 and 1 (each within the scatter of the next); then compound 3. At a limit, above all of these: compound 4.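

In this assay compound 4 gives > 100 nM, which is a limit of the assay and not a number: the limit of > 100 nM in this assay, at which 1 of the 4 values shown sits. Among the compounds shown here, the step to amino is an at least 33-fold higher number from compound 3 to compound 4 (1.52 log units; beyond the scatter), and the other two steps are an at least 160-fold higher number from compound 1 to compound 4 (2.22 log units; beyond the scatter) and an at least 330-fold higher number from compound 2 to compound 4 (2.52 log units; beyond the scatter), all larger than the widest gap among the earlier compounds, a 10-fold higher number from compound 2 to compound 3 (1.00 log units; beyond the scatter). Chloro, trifluoromethyl and nitro had suggested that this position accepts quite different groups with only modest changes, but amino shows that one small exchange here can cost most of the inhibition, so compound 4 is the weakest of the set, and of nitro and amino only amino carries a hydrogen-bond donor.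

A single compound cannot show whether the loss belongs to the amine itself or to any hydrogen-bond donor at this place, and a hydroxyl, a methylamino group or an acetamide on the same carbon would help to separate these readings. From the compounds shown here alone, how much weaker compound 4 really is also stays open, since its limit gives no exact value.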